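Swapping methyl for chloro on the anilide ring

The source may hold more compounds than are shown below. What is called first, only, known or untested is meant among the compounds shown, and "the series" means these compounds.

Measured so far, in an assay on cells for inhibition of Amine oxidase [flavin-containing] B (Homo sapiens), read by fluorescence and Amplex Red, using microsomes, with a stated time of 15 min; on this read-out higher numbers stand for weaker inhibition and lower numbers for stronger inhibition:
- compound 1 `Cc1ccc2occ(C(=O)Nc3cccc(Cl)c3)c(=O)c2c1` gives 4.2 nM
- compound 2 `COc1ccc2occ(C(=O)Nc3ccccc3)c(=O)c2c1` gives 41.8 nM
- compound 3 `COc1ccc2occ(C(=O)Nc3cccc(C)c3)c(=O)c2c1` gives 21.8 nM

Compound 3 stands second highest of the three numbers, close to compound 2 and well apart from compound 1, which sits lowest. For the measured compounds named here, the one single-point step known so far is a 1.9-fold lower number from compound 2 to compound 3 (0.28 log units; within the scatter). Compound 4 `COc1ccc2occ(C(=O)Nc3cccc(Cl)c3)c(=O)c2c1` differs from compound 3 by chloro in place of methyl on an aromatic carbon. Going by the values given here, no measured step covers that exact swap, so the expectation rests on compound 1, which carries the same chloro group on its anilide ring and gives 4.2 nM. Compound 4 is therefore expected to show a moderate step downward, a 2.7-fold lower number from compound 3 to compound 4 (0.44 log units; beyond the scatter), to an estimated 8 nM with a range from 3 nM to 25 nM.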

Compound 4, half-maximal inhibitory concentration: 3.94 nM
Estimate against measurement, compound 4: 2.0-fold (0.31 log units) above; measured number inside the range.
By their numbers in this assay, from the lowest: compounds 4 and 1 (each within the scatter of the next); then compounds 3 and 2 (each within the scatter of the next).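

In this assay, chloro and methyl at this position are clearly not interchangeable, with a 5.5-fold lower number from compound 3 to compound 4 (0.74 log units; beyond the scatter), and chloro in place of hydrogen gives an 11-fold lower number from compound 2 to compound 4 (1.03 log units; beyond the scatter), whereas methyl in place of hydrogen gave only a 1.9-fold lower number from compound 2 to compound 3 (0.28 log units; within the scatter). With chloro on the anilide ring, methoxy in place of methyl on the core leaves the two compounds indistinguishable, at a 1.1-fold lower number from compound 1 to compound 4 (0.03 log units; within the scatter). Nothing available gives a reason for the gain with chloro. As far as these compounds go, whether fluoro, bromo or trifluoromethyl at this position would match chloro remains open.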